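The source may report more compounds than this note shows. Statements on the series, on what has been measured and on what is new or still open speak of the compounds shown alone.

Compound 2 `COc1cc(C(=O)/C=C/c2cc(O)ccc2O)cc(OC)c1OC` gives only a limit in a functional assay on HepG2 cells (Homo sapiens) for inhibition, read by MTT assay, with a stated time of 48 h (a lower number here means a stronger inhibitor, a higher number a weaker inhibitor), > 100000 nM. That is the limit of > 100000 nM in this assay, at which 1 of the 3 values shown sits. On the same core, compound 1 `COc1cccc(/C=C/C(=O)c2cc(OC)c(OC)c(OC)c2)c1OC` gives 11500 nM and compound 3 `COc1cccc(/C=C/C(=O)c2cc(OC)c(OC)c(OC)c2)c1O` gives 13500 nM. Compound 4 `COc1cc(C(=O)/C=C/c2ccc(C)cc2)cc(OC)c1OC` differs from compound 2 by 4-methylphenyl in place of 2,5-dihydroxyphenyl on a double-bonded chain carbon bound to a double-bonded chain carbon, which is 4-methylphenyl in place of 2,5-dihydroxyphenyl. Within the data shown here, no measured step makes this swap. The nearest guide is a 1.2-fold higher number from compound 1 to compound 3 (0.07 log units; within the scatter), a small step for a change elsewhere on that ring type. Compound 4 is therefore expected to sit nearer compound 3, at 13500 nM, than compound 2. The expected change, towards a stronger inhibitor, is an at least 5.0-fold lower number from compound 2 to compound 4 (0.69 log units; beyond the scatter). For compound 4 the estimate is 20000 nM, with an expected range of 6000 nM to 70000 nM.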

Compound 4, half-maximal inhibitory concentration: 52000 nM
Compound 4: the middle estimate sits 2.6-fold (0.41 log units) below what was measured; the measured number falls inside the stated range.
By their numbers in this assay, from the lowest: compounds 1 and 3 (each within the scatter of the next); then compound 4. At a limit, above all of these: compound 2.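

Compound 2 gives only a limit in this assay: the limit of > 100000 nM in this assay, at which 1 of the 4 values shown sits.

As far as these compounds go, replacing 2,5-dihydroxyphenyl with 4-methylphenyl at this place gives an at least 1.9-fold lower number from compound 2 to compound 4 (0.28 log units; that floor lies within the scatter), so the true size of this change stays unknown: it could be small or much larger. Even so, this is the first step shown at this place, and a ring with no hydrogen-bond donors returns a number rather than a limit.

From the compounds shown here alone, whether any difference follows the hydroxyl groups leaving or the methyl entering stays open, as both change in this one step. Going by these compounds, how an amine in place of that methyl would read is also open.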